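This account rests on a few compounds, and the source may have more. Where it says the series, first, only, none or still open, it means among the compounds named here.

Measured in a functional assay on K562 cells (Homo sapiens) for inhibition, read by MTT assay, with a stated time of 96 h; a higher number here means a weaker inhibitor, a lower number a stronger inhibitor:
compound 1 `COCCOc1ccc(/C=C/C(=O)Nc2nc(-c3c(C)cc(C)cc3C)cs2)cc1`, 1490 nM
compound 2 `Cc1cc(C)c(-c2csc(NC(=O)/C=C/c3ccc(Br)cc3)n2)c(C)c1`, 4590 nM
compound 3 `Cc1cc(C)c(-c2csc(NC(=O)/C=C/c3ccc(C(F)(F)F)cc3)n2)c(C)c1`, 480 nM

Compound 3 stands lowest of the three; the nearest is compound 1 at a 3.1-fold lower number from compound 1 to compound 3 (0.49 log units; beyond the scatter) and the furthest compound 2 at a 9.6-fold lower number from compound 2 to compound 3 (0.98 log units; beyond the scatter). Compound 4 `Cc1cc(C)c(-c2csc(NC(=O)/C=C/c3ccc(N4CCCCC4)cc3)n2)c(C)c1` differs from compound 3 by piperidin-1-yl in place of trifluoromethyl on an aromatic carbon. Both measured steps that end at compound 3 involve the same aromatic carbon, and each replacement of another group by trifluoromethyl lowered the number, by a 3.1-fold lower number from compound 1 to compound 3 (0.49 log units; beyond the scatter) and a 9.6-fold lower number from compound 2 to compound 3 (0.98 log units; beyond the scatter). Taking trifluoromethyl away again is therefore expected to raise the number in this assay, by a modest step comparable to the smaller of those two. The estimate for compound 4 is 1500 nM, range 500 nM to 6000 nM, meaning an expected 3.1-fold higher number from compound 3 to compound 4 (0.49 log units; beyond the scatter).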

Compound 4, half-maximal inhibitory concentration: 4060 nM
For compound 4 the middle estimate is 2.7-fold (0.43 log units) below the measured one; the range from low to high includes it.
By their numbers in this assay, from the lowest: compound 3; then compound 1; then compounds 4 and 2 (each within the scatter of the next).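

In this assay piperidin-1-yl, the first ring placed on this aromatic carbon, gives up most of the gain seen with trifluoromethyl, with an 8.5-fold higher number from compound 3 to compound 4 (0.93 log units; beyond the scatter) as the largest new step. Exchange for bromo does not separate the two groups, with a 1.1-fold lower number from compound 2 to compound 4 (0.05 log units; within the scatter) in this pair, whereas exchange for 2-methoxyethoxy still gives a 2.7-fold higher number from compound 1 to compound 4 (0.44 log units; beyond the scatter) at this position. Trifluoromethyl therefore remains the group with the lowest number among the four. Morpholine, dimethylamino or nitrile at this carbon would show whether the ring, the nitrogen or neither governs the change. No measured data on hand account for these steps.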